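The compounds below may be only part of what the source reports. "The series", "measured", "known", "first", "only" and "open" are said of these compounds alone.

Values measured in an ADME assay on HEK293 cells (Homo sapiens) for cytotoxicity, read by reporter gene assay and resazurin assay, with a stated time of 48 h; a lower number here means that less compound is tolerated, a higher number that more compound is tolerated:
- compound 1 `O=C(Nc1cccc(Cl)c1)c1cc(Br)cc(Br)c1O`: 18000 nM
- compound 2 `O=C(Nc1ccc(Sc2nc3ccccc3s2)c(Cl)c1)c1cccc(Br)c1`: > 100000 nM
- compound 3 `O=C(Nc1ccc(Sc2nc3ccccc3s2)cc1)c1cccc(Br)c1`: 74000 nM

Compound 2 has no exact number, only a limit of this assay, namely > 100000 nM. Compound 4 `COc1ccc(Br)cc1C(=O)Nc1ccc(Sc2nc3ccccc3s2)c(Cl)c1` differs from it in one place: methoxy in place of hydrogen on an aromatic carbon. In words, methoxy stands in place of hydrogen on an aromatic carbon.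

Among the measured compounds shown here, only one measured step starts from compound 2: an at least 1.3-fold lower number from compound 2 to compound 3 (0.13 log units; that floor lies within the scatter). It swaps chloro for hydrogen, a different change, so it offers only weak guidance. For the measured compounds named here, no measured step tests methoxy. No shift beyond the scatter is therefore expected, and any shift would more likely be downward. The estimated step is an at least 1.3-fold lower number from compound 2 to compound 4 (0.12 log units; that floor lies within the scatter). For compound 4 the estimated value is 75000 nM, with an expected range from 30000 nM to 120000 nM.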

Compound 4, half-maximal cytotoxic concentration: > 100000 nM
Compound 4: a limit, no number; the forecaster's own chance of this, stated with the estimate: 40%; middle value at least 1.3-fold (0.12 log units) from the limit.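

Compound 2 and compound 4 both give only a limit in this assay, not a number, so the step between them cannot be read: the limit of > 100000 nM in this assay, at which 2 of the 4 values shown sit.

The compounds shown leave open whether methoxy in place of hydrogen changes how much compound is tolerated.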